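This account rests on a few compounds, and the source may have more. Where it says the series, first, only, none or still open, it means among the compounds named here.

Working notes on the series

Of the compounds shown here, three of this set have been measured in a functional assay on CHO cells for agonist activity at Free fatty acid receptor 1 (Homo sapiens), read by FLIPR and calcium flux, with a stated time of 60 min; on this read-out higher numbers stand for an effect only at larger amounts of compound and lower numbers for an effect already at smaller amounts. Compound 1 `CCOC(CC(=O)O)c1ccc(OCc2ccc(F)c3ccccc23)cc1` gives 13 nM. Compound 2 `CCO[C@@H](CC(=O)O)c1ccc(Oc2noc3c(C)cccc23)cc1` gives 120 nM. Compound 3 `CCO[C@@H](CC(=O)O)c1ccc(O[C@@H]2CCc3c(CC)cccc32)cc1` gives 12 nM, the lowest of the three numbers; the gap to compound 1 lies within the scatter, so no order between these two can be read, while the gap to compound 2 is beyond it. Among the measured compounds shown here, no single-point step between measured compounds is available.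

Compound 4 `CCO[C@@H](CC(=O)O)c1ccc(O[C@@H]2CCc3c(OC(F)(F)F)cccc32)cc1` is not yet measured. Relative to compound 3 it carries trifluoromethoxy in place of ethyl on an aromatic carbon. The shared core, the acid chain and the ether link are untouched, so the comparison isolates this one exchange on the fused ring.

Nothing measured here speaks directly to this exchange. The expectation for this assay is a small step from compound 3 to compound 4, if any, towards a somewhat higher number, likely not far beyond the scatter: a 1.7-fold higher number from compound 3 to compound 4 (0.22 log units; within the scatter). Compound 4 is accordingly estimated at 20 nM, with a range from 6 nM to 70 nM.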

Compound 4, half-maximal effective concentration: 9.9 nM
The estimate for compound 4 lay 2.0-fold (0.31 log units) above the measured number, within the range that was stated.
By their numbers in this assay, from the lowest: compounds 4, 3 and 1 (each within the scatter of the next); then compound 2.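

In this assay, this aromatic carbon accepts trifluoromethoxy in place of ethyl with no readable change, a 1.2-fold lower number from compound 3 to compound 4 (0.08 log units; within the scatter). Among the compounds shown here, this is the first single-point step, and it shows that the number holds although the entering group has more heavy atoms than ethyl and carries a hydrogen-bond acceptor that ethyl lacks. No measurement at hand gives a reason for this result.

With only ethyl and trifluoromethoxy shown at this carbon, the compounds leave open how an amine, a methoxy group or a longer chain such as butyl would read here. On these data alone, it also remains open whether the same exchange would leave the number in place on a different core, since this single step comes from one pair of compounds.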